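Hydroxy-bearing aliphatic amides on the shared core

This account rests on a few compounds, and the source may have more. Where it says the series, first, only, none or still open, it means among the compounds named here.

Notes on the amide side chain. Compound 1 `CC1(C)Cc2c(sc(NC(=O)c3ccn[nH]3)c2C(N)=O)C(C)(C)O1` carries a 1H-pyrazol-5-yl group on the carbonyl carbon; in an assay on cells for positive allosteric modulation of Cystic fibrosis transmembrane conductance regulator variant F508del (Homo sapiens), with stated times of 10 min and 7 s, in the presence of a further agent that is not named here (on this read-out higher numbers stand for an effect only at larger amounts of compound and lower numbers for an effect already at smaller amounts), compound 1 gives 3 nM. For the measured compounds named here, compound 2 `CC1(C)Cc2c(sc(NC(=O)C3(CO)CC3)c2C(N)=O)C(C)(C)O1`, with 1-(hydroxymethyl)cyclopropyl on the carbonyl carbon, gives 15 nM in this assay, the higher of the two numbers measured; the single step, a 5.0-fold higher number from compound 1 to compound 2 (0.70 log units; beyond the scatter), goes beyond the scatter. Compound 3 `CC1(C)Cc2c(sc(NC(=O)[C@H](O)C(C)(C)C)c2C(N)=O)C(C)(C)O1` is the next in line and differs from compound 2 by 1-hydroxy-2,2-dimethylpropyl in place of 1-(hydroxymethyl)cyclopropyl on a carbonyl carbon. Going by the values given here, the one measured step swaps an aromatic ring for a hydroxy-bearing aliphatic group, whereas the move to compound 3 keeps a hydroxy-bearing aliphatic group, so that step bears on it only loosely. No step beyond the scatter is therefore expected for compound 3, the estimated step being a 1.3-fold higher number from compound 2 to compound 3 (0.12 log units; within the scatter). Compound 3 is expected to give 20 nM, within a range from 7 nM to 60 nM in this assay.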

Compound 3, half-maximal effective concentration: 127 nM
Beside the measured number, compound 3's estimate is 6.4-fold (0.80 log units) below it; the whole stated range lies below it.
By their numbers in this assay, from the lowest: compound 1; then compound 2; then compound 3.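

On this carbonyl carbon, exchanging one hydroxy-bearing aliphatic group for another is not neutral in this assay and gives an 8.5-fold higher number from compound 2 to compound 3 (0.93 log units; beyond the scatter) when the open-chain 1-hydroxy-2,2-dimethylpropyl, with its defined stereocentre, replaces the three-membered ring of 1-(hydroxymethyl)cyclopropyl. Set against the 1H-pyrazol-5-yl group of compound 1, the same open-chain group gives a 42-fold higher number from compound 1 to compound 3 (1.63 log units; beyond the scatter) and so places compound 3 last of the three, after compound 1 and compound 2. No evidence at hand bears on either step.

The compounds shown leave open whether the ring, the branching or the configuration of the stereocentre carries the difference between compound 2 and compound 3. Also open, going by these compounds, is how an amine or a carboxylic acid in place of the hydroxy group would read in this assay on this carbonyl carbon.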